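Swapping a Saturated Ring for Isopropyl on a Shared Core

This account rests on a few compounds, and the source may have more. Where it says the series, first, only, none or still open, it means among the compounds named here.

Compound 1 `O=C(c1ccccc1)c1ccc2nc(NCCO)[nH]c2c1`, compound 2 `CN1CCC(Cn2c(N)nc3ccc(C(=O)c4ccccc4)cc32)CC1` and compound 3 `Nc1nc2ccc(C(=O)c3ccccc3)cc2n1C[C@@H]1CCCN1` share one core and were each tested in an ADME assay on HL-60 cells (Homo sapiens) for cytotoxicity, read by resazurin assay, with a stated time of 72 h; a lower number here means that less compound is needed, a higher number that more compound is needed for the effect. In this assay compound 1 gives > 30000 nM, which is a limit of the assay rather than a number. Compound 2 gives > 30000 nM, again a limit. Compound 3 gives > 30000 nM, once more a limit. Because every value sits at the limit of > 30000 nM in this assay, at which 3 of the 3 values shown sit, compound 3 cannot be ranked against the other two; it stands at the same limit as both. For the measured compounds named here, the only change between measured compounds, a step that the two limits leave unreadable from compound 2 to compound 3, therefore has no readable size.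

Compound 4 `CC(C)Cn1c(N)nc2ccc(C(=O)c3ccccc3)cc21` has not yet been measured. It differs from compound 3 in one place: isopropyl in place of pyrrolidin-2-yl on a saturated chain carbon bound to an aromatic nitrogen. Going by the values given here, no measured step bears on this change, since the single step available sits between two limits and shows nothing of direction or size.

With three limits and no readable step, the expectation is that compound 4 will also reach the limit, so the estimated step of a number no higher from compound 3 to compound 4 (the limit leaves the size open) is no change beyond the scatter. For compound 4 the estimate in this assay is 30000 nM, with a range from 10000 nM to 100000 nM.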

Compound 4, half-maximal effective concentration: > 30000 nM
Compound 4 gave a limit, no number; the forecaster's own chance of this, stated with the estimate: 80%; the middle value sits exactly at the limit.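

The steps linking compound 4 to compound 3 and to compound 2 cannot be read, and no value in this assay stands apart from the others: the limit of > 30000 nM in this assay, at which 4 of the 4 values shown sit.

The compounds shown leave open how compound 2, compound 3 and compound 4 truly rank, and whether any group on a saturated chain carbon bound to an aromatic nitrogen would give a readable number.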